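Dimethoxyphenyl ketone replaces pyrrolyl ketone on a shared core

The source may hold more compounds than are shown below. What is called first, only, known or untested is meant among the compounds shown, and "the series" means these compounds.

Measured compounds:
compound 1 `COc1ccc(OC)c(C(=O)/C=C/c2cn(-c3ccccc3)nc2-c2ccsc2)c1`: 3400 nM
compound 2 `O=C(/C=C/c1cn(-c2ccccc2)nc1-c1cccnc1)c1cc[nH]c1`: 7400 nM

In a functional assay on HCT-116 cells (Homo sapiens) for inhibition, read by sulforhodamine B assay, with a stated time of 72 h (on this read-out higher numbers stand for weaker inhibition and lower numbers for stronger inhibition), compound 2 gives the higher of the two numbers; compound 1 sits closer to strong inhibition, and this gap lies beyond the scatter. Compound 3 `COc1ccc(C(=O)/C=C/c2cn(-c3ccccc3)nc2-c2cccnc2)cc1OC` is not yet measured. It differs from compound 2 by 3,4-dimethoxyphenyl in place of 1H-pyrrol-3-yl on a carbonyl carbon. Among the compounds with values here, no directly comparable step is known, but compound 1, which also carries a dimethoxyphenyl on the carbonyl, gives 3400 nM, so a move toward stronger inhibition is expected. Compound 3 is estimated at 3000 nM, with a range from 1000 nM to 9000 nM; this means an expected step of a 2.5-fold lower number from compound 2 to compound 3 (0.39 log units; beyond the scatter).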

Compound 3, half-maximal inhibitory concentration: 4300 nM
For compound 3 the middle estimate is 1.4-fold (0.16 log units) below the measured one; measured number inside the range.
By their numbers in this assay, from the lowest: compounds 1, 3 and 2 (each within the scatter of the next, the first and the last beyond it).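

On a carbonyl carbon, 3,4-dimethoxyphenyl in place of 1H-pyrrol-3-yl gives a 1.7-fold lower number from compound 2 to compound 3 (0.24 log units; within the scatter) in this assay. At this position, this read-out therefore does not separate the larger six-membered carbon ring from the five-membered ring with its hydrogen-bond donor. No supporting measurement bears on this result.

On these data alone, compound 1 differs from compound 3 in more than one place, so the contribution of each difference remains open. Also open, as far as these compounds go, is whether an aminophenyl group on the carbonyl carbon would give a number outside the scatter of compound 2.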